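This account rests on a few compounds, and the source may have more. Where it says the series, first, only, none or still open, it means among the compounds named here.

In a functional assay on A549 cells (Homo sapiens) for cytotoxicity; on this read-out higher numbers stand for weaker inhibition and lower numbers for stronger inhibition:
- compound 1 `COc1c(O)cc2c3c1C[C@@H](C)C[C@H](OC)[C@H](O3)[C@@H](C)/C=C(\C)[C@H](OC(N)=O)[C@@H](OC)CC/C=C(\C)C(=O)N2`: 65000 nM
- compound 2 `COc1c(O)cc2c3c1C[C@@H](C)C[C@H](OC)[C@H](O3)[C@@H](C)/C=C(\C)[C@H](OC(N)=O)[C@@H](OC)/C=C\C=C(/C)C(=O)N2`: 16000 nM
- compound 3 `COc1c(O)cc2c3c1C[C@@H](C)C[C@H](OC)[C@H](O3)[C@@H](C)/C=C(\C)[C@H](OC(N)=O)[C@@H](OC)/C=C/C=C(\C)C(=O)N2`: 37000 nM

Compound 3, at 37000 nM, sits in the upper part of this small set. Its number lies within the usual scatter of compound 1, while compound 2 stands clearly apart from it, as a 2.3-fold higher number from compound 2 to compound 3 (0.36 log units; beyond the scatter) shows.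

The next compound to be measured is compound 4 `COc1c(O)cc2c3c1C[C@@H](C)C[C@H](OC)[C@H](O3)[C@@H](C)/C=C(\C)[C@H](OC(N)=O)[C@@H](OC)/C=C\C=C(\C)C(=O)N2`. Nothing is added or removed on the way from compound 3, and the whole change is the two compounds have the same atoms and bonds and differ only in configuration as drawn: 2 of 9 stereo elements differ; a double bond is drawn E in compound 3 and Z in compound 4; a double bond is drawn E in compound 3 and Z in compound 4. Such a change alters only how the molecule is drawn in space, not which atoms it contains.

Among the compounds with values here, the one measured step that bears on this is a 2.3-fold higher number from compound 2 to compound 3 (0.36 log units; beyond the scatter), which is modest. It also involves a double bond switching between Z and E, and it comes with the fact that compounds 2 and 3 differ only in the configuration as drawn. In that step, the compound with the Z bond had the lower number. This suggests a small move towards a lower number for compound 4, although one step cannot show how a second switched bond would add to the first. A large jump is therefore not expected.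

The expected change is a 1.5-fold lower number from compound 3 to compound 4 (0.17 log units; within the scatter). Compound 4 is estimated at 25000 nM, with an expected range from 10000 nM to 60000 nM.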

Compound 4, half-maximal inhibitory concentration: 13000 nM
Beside the measured number, compound 4's estimate is 1.9-fold (0.28 log units) above it; low and high end bracket the measured number.
By their numbers in this assay, from the lowest: compounds 4 and 2 (each within the scatter of the next); then compounds 3 and 1 (each within the scatter of the next).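

In this assay, the change from compound 3 to compound 4 switches two double bonds at once and gives a clear shift: a 2.8-fold lower number from compound 3 to compound 4 (0.45 log units; beyond the scatter). Compound 2 now splits this change into two single switches, and they do not count equally: a 2.3-fold higher number from compound 2 to compound 3 (0.36 log units; beyond the scatter), whereas a 1.2-fold lower number from compound 2 to compound 4 (0.09 log units; within the scatter), so compounds 2 and 4 cannot be told apart and the double bond that separates them has no readable effect on this result. Almost all of the shift therefore goes with the one switch that separates compound 2 from compound 3, and since no atom enters or leaves, it can only be tied to the configuration of the double bonds: the fact that compounds 3 and 4 differ only in the configuration as drawn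

The compounds shown leave open whether this difference between the two double bonds would hold if an amine or a longer chain were carried on the shared core. They also leave open why configuration matters here at all, since the data shown give only these cell numbers and nothing about the shape the molecules take.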